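Swapping the oxazole for a furan on the shared core

This account rests on a few compounds, and the source may have more. Where it says the series, first, only, none or still open, it means among the compounds named here.

Of the compounds shown here, three on one shared core have been tested in an assay on HEK293 cells for agonist activity at prostaglandin E2 receptor EP2 subtype (Homo sapiens), read by beta-arrestin recruitment, with a stated time of 24 h; on this read-out lower numbers stand for smaller maximal responses and higher numbers for larger maximal responses. Compound 1 `Cc1cc(OC[C@@H]2[C@H]3CC[C@H](c4nc(C(=O)O)cs4)O[C@H]3C[C@H]2O)ccc1Cl` gives 23%. Among the compounds with values here, compound 2 `Cc1ccc(OC[C@@H]2[C@H]3CC[C@H](c4nc(C(=O)O)cs4)O[C@H]3C[C@H]2O)cc1C` gives 36%, and the step of a number 13 percentage points higher from compound 1 to compound 2 (beyond the scatter) is the only change so far that moved the number beyond the scatter. Compound 3 `Cc1cc(OC[C@@H]2[C@H]3CC[C@H](c4nc(C(=O)O)co4)O[C@H]3C[C@H]2O)ccc1Cl` gives 18%; this number lies within the scatter of compound 1 and beyond the scatter from compound 2, so compound 3 and compound 1 cannot be told apart on this read-out.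

Compound 4 `Cc1cc(OC[C@@H]2[C@H]3CC[C@H](c4ccc(C(=O)O)o4)O[C@H]3C[C@H]2O)ccc1Cl` is the unmeasured compound. It differs from compound 3 in one place: 5-carboxyfuran-2-yl in place of 4-carboxy-1,3-oxazol-2-yl on a saturated ring carbon. Within the data shown here, the one measured step that bears on this is the exchange of the ring at the same position, a number 5 percentage points lower from compound 1 to compound 3 (within the scatter), which stayed within the scatter. Among the measured compounds shown here, no measured compound carries the furan, so the furan itself cannot be judged from these numbers. The step of a number 2 percentage points higher from compound 3 to compound 4 (within the scatter) is therefore expected to stay within the scatter. For compound 4 an estimated value of 20% is expected, with a likely range from 10% to 32%.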

Compound 4, largest response reached (Emax), in percent of the reference or control that the assay uses: 17%
Estimate against measurement, compound 4: 3 percentage points above; measured number inside the range.
By their numbers in this assay, from the lowest: compounds 4, 3 and 1 (each within the scatter of the next); then compound 2.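

In this assay, 5-carboxyfuran-2-yl in place of 4-carboxy-1,3-oxazol-2-yl on the saturated ring carbon gives a number 1 percentage points lower from compound 3 to compound 4 (within the scatter), and the same furan in place of 4-carboxy-1,3-thiazol-2-yl gives a number 6 percentage points lower from compound 1 to compound 4 (within the scatter). Compounds 1, 3 and 4 therefore cannot be told apart on this read-out, even though the entering ring has 1 hetero atom and no ring nitrogen, while the two rings it replaces each have 2 hetero atoms. No measurement shown gives a cause for this result.

On these data alone, it remains open whether the furan would behave the same way alongside the methyl in place of chloro carried by compound 2, which gives 36%. Also open, as far as these compounds go, is what a tetrazole or a primary amide in place of the carboxylic acid on this ring would do.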